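The source may hold more compounds than are shown below. What is called first, only, known or untested is meant among the compounds shown, and "the series" means these compounds.

The shared core appears in compound 1 `O=C(C1=C(OC2CCCCC2)C(=O)N(CCCn2ccnc2)C1c1ccc(Br)cc1)c1ccccc1`, whose double-bonded ring carbon carries a cyclohexyloxy group, and in compound 3 `O=C(C1=C(Nc2ccc(OC(F)(F)F)cc2)C(=O)N(CCCn2ccnc2)C1c1ccc(Br)cc1)c1ccccc1`, where that position carries a (4-(trifluoromethoxy)phenyl)amino group instead. In a functional assay on A549 cells (Homo sapiens) for antiproliferative activity, read by MTT assay, with a stated time of 72 h (a lower number here means a stronger inhibitor, a higher number a weaker inhibitor), compound 1 gives 31200 nM, and in this assay compound 3 gives 20800 nM; the step of a 1.5-fold lower number from compound 1 to compound 3 (0.18 log units; within the scatter), so the two stand together within the scatter. Compound 2 `NC1=C(C(=O)c2ccccc2)C(c2ccc(Br)cc2)N(CCCn2ccnc2)C1=O` carries a free amino group at the same ring carbon; in this assay compound 2 gives "not active" (no number reported), so no number stands for it. Compound 4 `O=C(C1=C(Nc2cccc(Br)c2)C(=O)N(CCCn2ccnc2)C1c1ccc(Br)cc1)c1ccccc1` differs from compound 2 by 3-bromophenyl in place of hydrogen on an amine nitrogen. Within the data shown here, no measured step tracks this exact change. The nearest guide is compound 3, which in this assay gives 20800 nM; its arylamino substituent resembles that of compound 4. Compound 4 is therefore expected to land near compound 3 rather than near the inactive compound 2, with an estimated value of 22000 nM in this assay, ranging from 8000 nM to 60000 nM.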

Compound 4, half-maximal inhibitory concentration: 15800 nM
Estimate against measurement, compound 4: 1.4-fold (0.14 log units) above; measured number inside the range.
By their numbers in this assay, from the lowest: compounds 4, 3 and 1 (each within the scatter of the next).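

In this assay, compound 2, with its free amino group, gives "not active" (no number reported), whereas compound 4, with (3-bromophenyl)amino at the same double-bonded ring carbon, gives 15800 nM, so placing 3-bromophenyl on this amine nitrogen goes with a measurable number. The identity of the group at this carbon matters little among the three compounds with numbers: a 1.3-fold lower number from compound 3 to compound 4 (0.12 log units; within the scatter), and a 2.0-fold lower number from compound 1 to compound 4 (0.30 log units; within the scatter), so the two arylamino groups and cyclohexyloxy cannot be told apart. No measurement shown here explains these results.

As far as these compounds go, it remains open whether a non-aromatic amine such as cyclohexylamino or morpholine at this ring carbon would also give a number. It is also unknown whether any group here could move the value beyond the scatter.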